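A Second Trifluoromethyl on the Amide Aryl Ring

The compounds below may be only part of what the source reports. "The series", "measured", "known", "first", "only" and "open" are said of these compounds alone.

Of the compounds shown here, three sharing one core have been tested in a functional assay on UACC-62 cells (Homo sapiens) for inhibition, read by sulforhodamine B assay, with a stated time of 48 h, tested at 10 uM; on this read-out lower numbers stand for a stronger effect and higher numbers for a weaker effect at the one concentration tested. Compound 3 `COc1cc(Cl)cc(-c2nn(-c3cccc(NC(=O)c4cccc(C(F)(F)F)c4)c3)cc2-c2ccncc2)c1` gives 74.5% in this assay. Compound 1 `COc1cc(Cl)cc(-c2nn(-c3cccc(NC(=O)c4ccc(Cl)c(Cl)c4)c3)cc2-c2ccncc2)c1` gives 75.4%, and compound 2 `COc1cc(Cl)cc(-c2nn(-c3cccc(NC(=O)Nc4ccc(Cl)c(C(F)(F)F)c4)c3)cc2-c2ccncc2)c1` gives 6.62%. Compound 3 thus stands second highest of the three numbers, close to compound 1 and far from compound 2.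

Compound 4 `COc1cc(Cl)cc(-c2nn(-c3cccc(NC(=O)c4cc(C(F)(F)F)cc(C(F)(F)F)c4)c3)cc2-c2ccncc2)c1` has not yet been measured. It differs from compound 3 in one place: trifluoromethyl in place of hydrogen on an aromatic carbon. The new group sits on an aromatic carbon of a six-membered aromatic ring of carbon only, meta to a trifluoromethyl group that is already present.

Which measured steps bear on this? The step of a number 0.9 percentage points lower from compound 1 to compound 3 (within the scatter) exchanged one aryl group on the carbonyl carbon for another and stayed within the scatter. The steps of a number 68.8 percentage points lower from compound 1 to compound 2 (beyond the scatter) and a number 67.9 percentage points higher from compound 2 to compound 3 (beyond the scatter) were large, but both involve exchanging an amino-bearing group for a plain aryl group on the carbonyl carbon, a different kind of change from adding a trifluoromethyl to an aryl ring. Among the measured compounds shown here, the nearest precedent is therefore the small first step, so the expected step of a number 1.5 percentage points lower from compound 3 to compound 4 (within the scatter) is small, with no change beyond the scatter. Compound 4 is estimated to give 73%, with a range from 55% to 90%.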

Compound 4, a percentage reported as activity, at one concentration (the size of the read-out at that concentration, not a potency): 81.4%
Compound 4: middle estimate off by 8.4 percentage points, on the low side, and the stated range covers the measured number.
By their numbers in this assay, from the lowest: compound 2; then compounds 3, 1 and 4 (each within the scatter of the next).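

In this assay, adding a trifluoromethyl to the aromatic ring, meta to the trifluoromethyl group already present, gives a number 6.9 percentage points higher from compound 3 to compound 4 (within the scatter), so this position accepts a second group of four heavy atoms without a change that can be told from ordinary scatter. The earlier pair of compound 1 and compound 3 showed the same for exchanging one whole aryl group for another on the carbonyl carbon, and this step extends that picture to adding a group to the ring, which falls far short of the size of a number 68.8 percentage points lower from compound 1 to compound 2 (beyond the scatter). Nothing measured here accounts for this flat result.

Going by these compounds, whether an amine or a carboxylic acid on this same ring carbon would move the read-out remains open, and a single added trifluoromethyl says little about such different groups. Also open, on these data alone, is whether a second trifluoromethyl would be accepted as quietly on the aryl ring of compound 2, which gives 6.62% in this assay, where there is a much stronger effect that could be lost.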